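Inverting one stereocentre of compound 2: cytotoxicity notes

The source may report more compounds than this note shows. Statements on the series, on what has been measured and on what is new or still open speak of the compounds shown alone.

In a toxicity assay on MT2 cells (Homo sapiens) for cytotoxicity, read by XTT assay, with a stated time of 4 days (on this read-out higher numbers stand for lower toxicity in this test and lower numbers for higher toxicity in this test), compound 1 (`Cc1ccc(-c2ccc(C(=O)N[C@@H](c3nc(C)c(CCO)s3)[C@@H]3CCCCN3)[nH]2)cc1F`) reads 21200 nM and compound 2 (`Cc1nc([C@@H](NC(=O)c2ccc(-c3ccc(Cl)c(F)c3)[nH]2)[C@@H]2CCCCN2)sc1CCO`) reads 16900 nM with the two lying within the scatter of each other. Compound 2 therefore stands level with compound 1 on these numbers. Compound 3 (`Cc1nc([C@H](NC(=O)c2ccc(-c3ccc(Cl)c(F)c3)[nH]2)[C@@H]2CCCCN2)sc1CCO`) is its stereoisomer: the two compounds have the same atoms and bonds and differ only in configuration as drawn: 1 of 2 stereo elements differ; a stereocentre at a saturated chain carbon is drawn S in compound 2 and R in compound 3 with nothing else altered. Among the measured compounds shown here, no measured pair isolates such a change, so no step beyond the scatter is expected in this assay in either direction. The expected 1.1-fold higher number from compound 2 to compound 3 (0.03 log units; within the scatter) stays within that scatter. Compound 3 is estimated at 18000 nM with a range from 8000 nM to 40000 nM on current data.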

Compound 3, half-maximal cytotoxic concentration: 16800 nM
The estimate for compound 3 lay 1.1-fold (0.03 log units) above the measured number; low and high end bracket the measured number.
By their numbers in this assay, from the lowest: compounds 3, 2 and 1 (each within the scatter of the next).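

Among the compounds shown here, the step of a 1.0-fold lower number from compound 2 to compound 3 (0.00 log units; within the scatter) gives the first reading of configuration alone at this saturated chain carbon, and drawn S and drawn R stand level in this assay. The pair is a clean test of that centre: the fact that compounds 2 and 3 differ only in the configuration as drawn. The step of a 1.3-fold lower number from compound 1 to compound 3 (0.10 log units; within the scatter), with chloro in place of methyl on an aromatic carbon, also stays within the scatter.

The compounds shown leave open whether the other stereo element, the same in all of them, matters in this assay. Also open, from the compounds shown here alone, is whether a carboxylic acid or an amine in place of the chloro would shift the number.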